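Vinylcarbonyl on the ring amine of compound 1

The compounds below may be only part of what the source reports. "The series", "measured", "known", "first", "only" and "open" are said of these compounds alone.

In a functional assay on SF-268 cells (Homo sapiens) for antiproliferative activity, read by sulforhodamine B assay, with a stated time of 48 h (a higher number here means a weaker inhibitor of growth, a lower number a stronger inhibitor of growth), compound 1 `O=C1/C(=C/c2ccc3ccccc3c2)CNC/C1=C\c1ccc2ccccc2c1` gives 6200 nM and compound 2 `O=C1/C(=C/c2c[nH]c3ccccc23)CNC/C1=C\c1c[nH]c2ccccc12` gives 3300 nM. Within the data shown here, these two values lie within the scatter of each other, so compound 1 cannot be separated from the only other measured member of the series. Compound 3 `C=CC(=O)N1C/C(=C\c2ccc3ccccc3c2)C(=O)/C(=C/c2ccc3ccccc3c2)C1` keeps the core of compound 1 and differs from it in one place: vinylcarbonyl in place of hydrogen on an amine nitrogen in a ring, with vinylcarbonyl in place of hydrogen on an amine nitrogen in a ring. Among the measured compounds shown here, no measured pair shows any change at this nitrogen, so the expectation is a judgment with wide uncertainty. A step beyond the scatter towards stronger growth inhibition is expected in this assay. The estimated change is a 4.1-fold lower number from compound 1 to compound 3 (0.62 log units; beyond the scatter). For compound 3 the estimated value is 1500 nM, with an expected range of 300 nM to 6000 nM.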

Compound 3, concentration for 50% growth inhibition: 600 nM
Compound 3: middle estimate off by 2.5-fold (0.40 log units), on the high side; low and high end bracket the measured number.
By their numbers in this assay, from the lowest: compound 3; then compounds 2 and 1 (each within the scatter of the next).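

Vinylcarbonyl on the ring amine nitrogen gives a 10-fold lower number from compound 1 to compound 3 (1.01 log units; beyond the scatter) in this assay, the first measured step at this position, and it is large. The hydrogen on this nitrogen is therefore not required for growth inhibition in this pair, and this position can change the number far more than the scatter allows. No measured evidence accounts for the size of this step.

The compounds shown leave open whether the step depends on the carbon-carbon double bond of vinylcarbonyl, or whether a propanoyl or acetyl group on the same nitrogen, which lacks it, would give a comparable number. On these data alone, it also remains open whether vinylcarbonyl on the ring nitrogen of compound 2 would produce a step of similar size.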